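The source may report more compounds than this note shows. Statements on the series, on what has been measured and on what is new or still open speak of the compounds shown alone.

Compound 1 `O=c1ccn(CCCCCOc2ccc(-c3ccccc3)cc2)c(=O)[nH]1` joins the shared core through a chain to an aromatic ring that bears a phenyl. In an ADME assay on HEL cells (Homo sapiens) for cytotoxicity (on this read-out lower numbers stand for higher toxicity in this test and higher numbers for lower toxicity in this test), compound 1 gives "not determined" (no result reported), so it has no number of its own to stand on. The one figure in this set comes from compound 2 `O=c1ccn(CCCCCCCCOc2ccc(Br)cc2)c(=O)[nH]1`. In this assay compound 2 gives > 100000 nM, which is a limit of the test rather than a number. The anchor for the series is thus the limit of > 100000 nM in this assay, at which 1 of the 2 values shown sits, alone. Compound 3 `Nc1ccc(OCCCCCn2ccc(=O)[nH]c2=O)cc1` differs from compound 1 by the change (amino in place of phenyl on an aromatic carbon), amino in place of phenyl on an aromatic carbon, para to a large group. No measured step covers this change, so its size and direction are unknown, and nothing shown points to a move beyond the usual scatter. Leaning on the limit of compound 2 (the limit of > 100000 nM in this assay, at which 1 of the 2 values shown sits), compound 3 is expected to give 100000 nM, within 30000 nM to 300000 nM.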

Compound 3, half-maximal cytotoxic concentration: > 100000 nM
Compound 3 ended at the assay's limit; the forecaster's own chance of this, stated with the estimate: 70%; the middle value sits exactly at the limit.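

Within the data shown here, no step from compound 1 to compound 3 can be read: compound 1 has no number of its own, and the result for compound 3 is a limit of the test, not a number. The compounds shown leave open what amino in place of phenyl does in this assay, and how far any of them lies past this shared limit: the limit of > 100000 nM in this assay, at which 2 of the 3 values shown sit.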